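The source may hold more compounds than are shown below. What is called first, only, known or untested is meant among the compounds shown, and "the series" means these compounds.

Compound 3 `Cc1cc(Br)ccc1NC(=O)COc1ccc2cc(/C=C3/SC(=O)NC3=O)ccc2c1` is one of three compounds sharing a common core that have been measured in an assay on isolated protein for inhibition of histone deacetylase 8 (Homo sapiens), with a stated time of 1 h; a higher number here means a weaker inhibitor, a lower number a stronger inhibitor. In this assay compound 3 gives 7400 nM. Compound 2 `O=C(COc1ccc2cc(/C=C3/SC(=O)NC3=O)ccc2c1)Nc1cccc(F)n1` gives 7200 nM in this assay. Compound 1 `O=C(COc1ccc2cc(/C=C3/SC(=O)NC3=O)ccc2c1)Nc1ccccn1` gives only a limit in this assay, > 50000 nM. On the numbers shown, compound 3 stands alongside compound 2, the step of a 1.0-fold higher number from compound 2 to compound 3 (0.01 log units; within the scatter) lying within the scatter, so the two are not distinguished.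

Compound 4 `O=C(COc1ccc2cc(/C=C3/SC(=O)NC3=O)ccc2c1)Nc1ccc(Cl)c(Cl)c1` has not yet been measured. It differs from compound 3 by 3,4-dichlorophenyl in place of 4-bromo-2-methylphenyl on an amide-type nitrogen. Within the data shown here, two measured steps concern a change at this amide-type nitrogen: an at least 6.7-fold lower number from compound 1 to compound 3 (0.82 log units; beyond the scatter) and a 1.0-fold higher number from compound 2 to compound 3 (0.01 log units; within the scatter). The first is only a bound on the size of the step, since compound 1 sits at a limit (the limit of > 50000 nM in this assay, at which 1 of the 3 values shown sits). The second, an exchange of one aryl group for another on the same nitrogen, produced no change beyond the scatter. The remaining step, an at least 6.9-fold lower number from compound 1 to compound 2 (0.84 log units; beyond the scatter), concerns a fluoro for hydrogen and also begins at the limit.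

As one carbon-only aromatic ring replaces another, compound 4 is expected to show no step beyond the scatter, a 1.1-fold lower number from compound 3 to compound 4 (0.02 log units; within the scatter). Compound 4 is therefore estimated at 7000 nM, within a range from 2000 nM to 30000 nM.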

Compound 4, half-maximal inhibitory concentration: > 50000 nM
Compound 4: a limit, no number (the forecaster's own chance of this, stated with the estimate: 20%); middle value at least 7.1-fold (0.85 log units) away from the limit.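

At this amide-type nitrogen, exchanging one carbon-only aromatic ring for another is not a silent change in this assay, even though the leaving and entering groups are equal in heavy atoms and neither carries a hydrogen-bond donor or acceptor: the change gives an at least 6.7-fold higher number from compound 3 to compound 4 (0.82 log units; beyond the scatter). The step from the 6-fluoropyridin-2-yl group reads an at least 6.9-fold higher number from compound 2 to compound 4 (0.84 log units; beyond the scatter), so compound 2 and compound 3, which could not be told apart from each other, both separate from compound 4, and the aryl group on this nitrogen can matter even where the earlier exchange between compound 2 and compound 3 showed nothing. Compound 4 gives > 50000 nM, which is a limit of the assay and not a number, so both steps are bounds on their size, and the step from compound 1 to compound 4 cannot be read, the two compounds sharing that limit: the limit of > 50000 nM in this assay, at which 2 of the 4 values shown sit.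

The 4-bromo-2-methylphenyl and 3,4-dichlorophenyl groups differ in more than one substituent, and the compounds shown do not tell which difference carries the step. On these data alone, it also remains open how an unsubstituted phenyl group, a 4-bromophenyl group or a phenyl ring bearing a carboxylic acid would read on this nitrogen.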